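Working notes: the step from compound 2 to compound 3

This account rests on a few compounds, and the source may have more. Where it says the series, first, only, none or still open, it means among the compounds named here.

compound 1 `CC(C)CCn1nc(-c2cccs2)c(O)c(C2=NS(=O)(=O)c3cc(NS(=O)(=O)C4CC4)ccc3N2)c1=O`: > 1000 nM (a limit)
compound 2 `CC(C)CCn1nc(-c2cccs2)c(O)c(C2=NS(=O)(=O)c3cc(N(C(C)C)S(C)(=O)=O)ccc3N2)c1=O`: "not determined" (no result reported)

In an ADME assay on Huh-7 cells (Homo sapiens) for cytotoxicity, with a stated time of 72 h (a higher number here means that more compound is tolerated, a lower number that less compound is tolerated), compound 1 gives > 1000 nM, which is a limit and not a number. Compound 2 gives "not determined" (no result reported) here, so it has no place on the scale and offers no number to step from. Next in the series is compound 3 `CC(C)CCn1nc(-c2cccs2)c(O)c(C2=NS(=O)(=O)c3cc(CS(C)(=O)=O)ccc3N2)c1=O`. The change (methylsulfonyl)methyl in place of isopropyl(methylsulfonyl)amino on an aromatic carbon puts (methylsulfonyl)methyl in place of isopropyl(methylsulfonyl)amino on an aromatic carbon. With no reading for compound 2, no step beyond the scatter is expected in this assay and no direction can be given. Compound 3 is estimated at 5000 nM, with an expected range of 1000 nM to 25000 nM.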

Compound 3, half-maximal cytotoxic concentration: > 33000 nM
Compound 3 was reported as a limit (the forecaster's own chance of this, stated with the estimate: 80%); middle value at least 6.6-fold (0.81 log units) away from the limit.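

No new step can be read in this assay: compound 1 and compound 3 are each reported only as a limit, and compound 2 has no result. The compounds shown leave open whether compound 1 and compound 3 differ at all in this assay.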